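Trimming the isopropyl to methyl at the carbinol carbon

The source may hold more compounds than are shown below. What is called first, only, known or untested is meant among the compounds shown, and "the series" means these compounds.

Compound 1 `CC(=O)Nc1cccc(-c2ccc(C(O)(c3c[nH]cn3)C(C)C)cc2)c1`: 17 nM
Compound 2 `CC(=O)Nc1cccc(-c2ccc([C@](O)(c3c[nH]cn3)C(C)C)cc2)c1`: 14 nM

In an assay on microsomes from Testis (strain Sprague-Dawley) for inhibition of steroid 17-alpha-hydroxylase/17,20 lyase (Rattus norvegicus) (on this read-out higher numbers stand for weaker inhibition and lower numbers for stronger inhibition), compound 1 gives 17 nM. Compound 2 gives 14 nM. The step of a 1.2-fold lower number from compound 1 to compound 2 (0.08 log units; within the scatter) lies within the scatter, and the two share every atom and bond; they differ only in that one stereocentre is drawn with a defined configuration in compound 2 alone (the fact that one of compounds 1 and 2 is drawn with a defined configuration and the other without, at the place where they differ). Compound 3 `CC(=O)Nc1cccc(-c2ccc(C(C)(O)c3c[nH]cn3)cc2)c1` carries methyl in place of isopropyl on a saturated chain carbon bound to two aromatic carbons and an oxygen on a saturated carbon. Within the data shown here, no measured step changes a group at that carbon, so the single measured step offers no guide here. Compound 3 is expected to give 40 nM (range 12 nM to 150 nM), an estimated step of a 2.4-fold higher number from compound 1 to compound 3 (0.37 log units; beyond the scatter).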

Compound 3, half-maximal inhibitory concentration: 62 nM
Estimate against measurement, compound 3: 1.6-fold (0.19 log units) below, within the range that was stated.
By their numbers in this assay, from the lowest: compounds 2 and 1 (each within the scatter of the next); then compound 3.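

Among these compounds, this is the first measured change to the group at this carbon, and in this assay methyl in place of isopropyl gives a 3.6-fold higher number from compound 1 to compound 3 (0.56 log units; beyond the scatter). Unlike the change in drawn configuration, this step lies beyond the scatter, so the read-out responds to the group at this position, with the smaller methyl giving weaker inhibition here. Nothing available explains this step.

On these data alone, whether ethyl would fall between methyl and isopropyl remains open, as does the effect of a larger tert-butyl group. Compound 3 is drawn without a defined configuration, so any difference between its two mirror-image forms is also unknown.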